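Methoxy on the Benzoate: Expected Effect on Antiproliferative Activity

The source may hold more compounds than are shown below. What is called first, only, known or untested is meant among the compounds shown, and "the series" means these compounds.

Measured compounds:
compound 1, `Cc1cc2c(C(C)C)ccc(C)c2cc1OC(=O)c1cccc(C(F)(F)F)c1`, reported in a functional assay on HCT-15 cells (Homo sapiens) for antiproliferative activity, read by sulforhodamine B assay, with a stated time of 48 h, tested at 50 uM (on this read-out higher numbers stand for more inhibition at the one concentration tested (going by the name of the read-out) and lower numbers for less inhibition), as "not active" (no number reported) (no number given)
compound 2, `CC1=CC[C@H](C(C)C)c2cc(C)c(OC(=O)c3ccccc3)cc21`, 49.5%

Compound 2 holds the only number shown in this assay; compound 1 stands beside it without a figure. Compound 3, `COc1ccc(C(=O)Oc2cc3c(cc2C)[C@@H](C(C)C)CC=C3C)cc1`, differs from compound 2 by methoxy in place of hydrogen on an aromatic carbon. No step between two measured compounds is shown, so no size for such a change can be taken from the data; the expectation is a step from compound 2 to compound 3 of no more than the usual scatter, in either direction. Compound 3 is therefore expected to give about 48%, somewhere between 30% and 65%, a step of a number 1.5 percentage points lower from compound 2 to compound 3 (within the scatter).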

Compound 3, a percentage reported as inhibition, at one concentration (the size of the read-out at that concentration, not a potency): 30.8%
Compound 3: the middle estimate sits 17.2 percentage points above what was measured; the measured number falls inside the stated range.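

In this assay, methoxy in place of hydrogen on an aromatic carbon, para to a large group, gives a number 18.7 percentage points lower from compound 2 to compound 3 (beyond the scatter). Going by these compounds alone, this is the first measured step at this position, and it shows that the position is not indifferent to change: going from phenyl to 4-methoxyphenyl lowers the inhibition read at the one concentration tested. Nothing measured here says why.

As far as these compounds go, whether an amine, a carboxylic acid or a longer chain on this same carbon would also lower the number stays open. A single step also cannot show whether any group here would raise it.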